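Swapping Trifluoromethyl for Carboxy: What to Expect

The source may hold more compounds than are shown below. What is called first, only, known or untested is meant among the compounds shown, and "the series" means these compounds.

Measured so far:
compound 1, `Cc1n[nH]c(C(=O)O)c1Cc1cccc(C(F)(F)F)c1`, gives 5% in an assay on isolated protein for inhibition of 2-Hydroxyacid oxidase 2 (Homo sapiens), tested at 1 uM; a lower number here means a weaker effect, a higher number a stronger effect of the compound at the concentration tested
compound 2, `Cc1n[nH]c(C(=O)O)c1Cc1ccc(Oc2ccccc2)cc1`, gives 10% in this assay
compound 3, `Cc1n[nH]c(C(=O)O)c1Cc1ccc(-c2ccc(OC(F)(F)F)cc2)cc1`, gives 11% in this assay

Compound 1 carries the lowest of the three numbers, but compound 2 and compound 3 both lie within the usual scatter of it, so no order among the three can be read; all show only slight inhibition at this concentration.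

Compound 4, `Cc1n[nH]c(C(=O)O)c1Cc1cccc(C(=O)O)c1`, is not yet measured. It differs from compound 1 in one place: carboxy in place of trifluoromethyl on an aromatic carbon. For the measured compounds named here, no measured pair differs in a single place, so no step can guide the expectation. In this assay a move of no more than the scatter is expected, in either direction. For compound 4 the estimate is 8%, with a range from 0% to 25%. The expected step of a number 3 percentage points higher from compound 1 to compound 4 (within the scatter) is thus small.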

Compound 4, a percentage reported as inhibition, at one concentration (the size of the read-out at that concentration, not a potency): 3%
The estimate for compound 4 lay 5 percentage points above the measured number, and the stated range covers the measured number.
By their numbers in this assay, from the lowest: compounds 4, 1, 2 and 3 (each within the scatter of the next).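

For the compounds shown here, this is the first comparison that differs in one place: carboxy in place of trifluoromethyl on an aromatic carbon gives a number 2 percentage points lower from compound 1 to compound 4 (within the scatter) in this assay. At this position, then, a group with a hydrogen-bond donor and acceptor and a group with neither cannot be told apart, and both compounds show only slight inhibition. Nothing available explains this result. As far as these compounds go, whether an amine or a longer chain on this aromatic carbon would stand apart from compound 1 remains open.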